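Title: From one fluorine to two on the pendant phenyl ring

The source may hold more compounds than are shown below. What is called first, only, known or untested is meant among the compounds shown, and "the series" means these compounds.

Measured so far:
- compound 1 `COc1cc(C2=NN(C(C)=O)C(c3cc(Cl)cc(Cl)c3)O2)cc(OC)c1OC`: 93.9%
- compound 2 `COc1cc(C2=NN(C(C)=O)C(c3ccc(C(F)(F)F)cc3)O2)cc(OC)c1OC`: -0.7%
- compound 3 `COc1cc(C2=NN(C(C)=O)C(c3ccccc3F)O2)cc(OC)c1OC`: 31.6%

In a functional assay on PC-3 cells (Homo sapiens) for antiproliferative activity, read by MTT assay, tested at 5 uM (a lower number here means a weaker effect, a higher number a stronger effect of the compound at the concentration tested), compound 3 gives 31.6%, the second highest of the three numbers. Its nearest neighbour is compound 2, and the step of a number 32.3 percentage points higher from compound 2 to compound 3 (beyond the scatter) lies beyond the scatter; the step of a number 62.3 percentage points lower from compound 1 to compound 3 (beyond the scatter) is larger still and runs the other way, so compound 3 sits well apart from both.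

Compound 4 `COc1cc(C2=NN(C(C)=O)C(c3ccc(F)c(F)c3)O2)cc(OC)c1OC` is not yet measured. The change from compound 3 is 3,4-difluorophenyl in place of 2-fluorophenyl on a saturated ring carbon.

Every measured step here swaps one aryl group on that saturated ring carbon for another, so all three bear on this change. They are large: a number 94.6 percentage points lower from compound 1 to compound 2 (beyond the scatter), a number 62.3 percentage points lower from compound 1 to compound 3 (beyond the scatter) and a number 32.3 percentage points higher from compound 2 to compound 3 (beyond the scatter). The highest number belongs to compound 1, whose ring carries two chlorines; the lowest to compound 2, whose ring carries a trifluoromethyl group. A ring with two fluorines is estimated to land between compound 3 and compound 1, so a moderate upward step a number 13.4 percentage points higher from compound 3 to compound 4 (beyond the scatter) is expected, though the spread of the measured swaps makes this uncertain. For compound 4 the estimate is 45%, with a range from 5% to 85%.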

Compound 4, a percentage reported as inhibition, at one concentration (the size of the read-out at that concentration, not a potency): 46.9%
Estimate against measurement, compound 4: 1.9 percentage points below; low and high end bracket the measured number.
By their numbers in this assay, from the lowest: compound 2; then compound 3; then compound 4; then compound 1.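

In this assay, the swap to 3,4-difluorophenyl gives a number 15.3 percentage points higher from compound 3 to compound 4 (beyond the scatter), so this position still responds to a change as small as going from one fluorine to two, although the swap alters both the number of fluorines and where they stand, and this single step cannot separate the two. The larger steps, a number 47.6 percentage points higher from compound 2 to compound 4 (beyond the scatter) and a number 47 percentage points lower from compound 1 to compound 4 (beyond the scatter), place compound 4 well clear of both ends of the series, which shows that a ring with two halogens does not by itself reach the level of compound 1, since the 3,4-difluorophenyl and 3,5-dichlorophenyl rings differ in both the halogen and its placement. Nothing available here explains why these aryl groups give such different numbers.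

As far as these compounds go, a 3,5-difluorophenyl group would keep the placement of compound 1 and change only the halogen, so its result would help to separate those two factors, and how far the trend holds for a single fluorine in other places on the ring remains open. Also open, from the compounds shown here alone, is how a phenyl ring carrying an amine or a carboxylic acid would behave at this position in this assay.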